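Amine to anilide: a fluorophenyl group on compound 3

A few compounds are considered here, and "the series" means these few. Any claim that something is new, unique, unknown or untested is made for them only; others in the source may bear on it.

Of the compounds shown here, three that share one core have been tested in a functional assay on NCI-H1299 cells (Homo sapiens) for antiproliferative activity, read by MTT assay, with a stated time of 72 h; a lower number here means a stronger inhibitor, a higher number a weaker inhibitor. Compound 1 `CCCCCOC1=C(C(=O)c2ccccc2)C(c2ccc(Br)cc2)N(CCCn2ccnc2)C1=O` gives 10300 nM, and compound 2 `CCCCOC1=C(C(=O)c2ccccc2)C(c2ccc(Br)cc2)N(CCCn2ccnc2)C1=O` gives 17100 nM; the step of a 1.7-fold higher number from compound 1 to compound 2 (0.22 log units; within the scatter) separates them. Compound 3 `NC1=C(C(=O)c2ccccc2)C(c2ccc(Br)cc2)N(CCCn2ccnc2)C1=O` gives 169000 nM, the highest of the three numbers; it is reached by a 16-fold higher number from compound 1 to compound 3 (1.22 log units; beyond the scatter) and by a 9.9-fold higher number from compound 2 to compound 3 (0.99 log units; beyond the scatter), so the amino group sits well behind both alkoxy groups in this assay.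

Compound 4 `O=C(C1=C(Nc2ccc(F)cc2)C(=O)N(CCCn2ccnc2)C1c1ccc(Br)cc1)c1ccccc1` differs from compound 3 by 4-fluorophenyl in place of hydrogen on an amine nitrogen. Going by the values given here, none of the measured steps alters the amine nitrogen itself, so no direct precedent exists; the two steps that bear on the amine position both show that compound 3 is the weakest point among the three, and the only change at that position that has been seen is one that moved away from the plain amino group. On that basis a moderately lower number is expected for compound 4, with the step of a 6.8-fold lower number from compound 3 to compound 4 (0.83 log units; beyond the scatter) estimated from compound 3. Compound 4 is thus expected to show 25000 nM in this assay, within a range from 6000 nM to 100000 nM.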

Compound 4, half-maximal inhibitory concentration: 25400 nM
For compound 4 the middle estimate is 1.0-fold (0.01 log units) below the measured one; the measured number falls inside the stated range.
By their numbers in this assay, from the lowest: compounds 1, 2 and 4 (each within the scatter of the next, the first and the last beyond it); then compound 3.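

In this assay the amine nitrogen proves to be a position where a substituent pays: 4-fluorophenyl in place of hydrogen gives a 6.7-fold lower number from compound 3 to compound 4 (0.82 log units; beyond the scatter), so most of the loss seen with the plain amino group is regained without any oxygen link at this carbon. Against the butoxy group, the (4-fluorophenyl)amino group shows a 1.5-fold higher number from compound 2 to compound 4 (0.17 log units; within the scatter), which separates neither, while against the pentyloxy group it shows a 2.5-fold higher number from compound 1 to compound 4 (0.39 log units; beyond the scatter) and so still falls short of that chain. Nothing at hand explains these steps.

The compounds shown leave open how much of the gain belongs to the ring and how much to its fluorine, a question that a plain phenyl group on the same nitrogen would address. They also leave open how a benzyl group or a simple alkyl chain on that nitrogen would read.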